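A few compounds are considered here, and "the series" means these few. Any claim that something is new, unique, unknown or untested is made for them only; others in the source may bear on it.

Compound 1 `Cc1ccc(/C=C(\C(=O)c2ccc([N+](=O)[O-])cc2)S(=O)(=O)Cc2ccc(Cl)cc2)s1` gives 25000 nM in a functional assay on DU-145 cells (Homo sapiens) for inhibition, read by trypan blue exclusion, with a stated time of 96 h (a higher number here means a weaker inhibitor of growth, a lower number a stronger inhibitor of growth), and compound 2 `O=C(/C(=C\c1ccc(Cl)c([N+](=O)[O-])c1)S(=O)(=O)c1ccc(Br)cc1)c1ccc(Br)cc1` gives 10000 nM there, both being sulfonyl compounds. Compound 3 `COc1cc(OC)c(/C=C(/Sc2ccc(C)cc2)C(=O)c2ccc(Cl)cc2)c(OC)c1` stands at > 100000 nM as a limit of the assay and not a number, the only such result of the three. Compound 4 `COc1cc(OC)c(/C=C(\C(=O)c2ccc(Cl)cc2)S(=O)(=O)c2ccc(Br)cc2)c(OC)c1` differs from compound 3 in one place ((4-bromophenyl)sulfonyl in place of (4-methylphenyl)sulfanyl on a double-bonded chain carbon bound to a carbonyl carbon and a double-bonded chain carbon) with (4-bromophenyl)sulfonyl in place of (4-methylphenyl)sulfanyl on a double-bonded chain carbon bound to a carbonyl carbon and a double-bonded chain carbon. For the measured compounds named here, no measured pair isolates this change. Compound 2 also carries (4-bromophenyl)sulfonyl, and its 10000 nM suggests that a large gain in growth inhibition in this assay is expected, not a step within the scatter. The expected move is an at least 12-fold lower number from compound 3 to compound 4 (1.09 log units; beyond the scatter) in size. For compound 4 the estimated concentration is 8000 nM and the expected range runs from 1000 nM to 50000 nM in this read-out.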

Compound 4, concentration for 50% growth inhibition: > 100000 nM
Compound 4 gave a limit, no number (the forecaster's own chance of this, stated with the estimate: 10%); at least 12-fold (1.09 log units) between middle value and limit.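

Compound 3 and compound 4 both stand at a limit of this assay, not at a number, so no step can be read between them: the limit of > 100000 nM in this assay, at which 2 of the 4 values shown sit. The compounds shown leave open whether (4-bromophenyl)sulfonyl in place of (4-methylphenyl)sulfanyl changes growth inhibition at all, and by how much.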